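Aryl variation on the enone of the shared core

The source may hold more compounds than are shown below. What is called first, only, known or untested is meant among the compounds shown, and "the series" means these compounds.

Compound 1 `Cc1cc(Nc2ccc(C(=O)/C=C/c3ccc(F)cc3)cc2)n2nc(SCc3nc4ccccc4[nH]3)nc2n1` gives 85 nM in a functional assay on SW-620 cells (Homo sapiens) for cytotoxicity, read by MTT assay, with stated times of 4 h and 72 h, tested at 2 uM; on this read-out lower numbers stand for stronger inhibition and higher numbers for weaker inhibition.
Compound 2 `Cc1cc(Nc2ccc(C(=O)/C=C/c3ccc(OC(F)(F)F)cc3)cc2)n2nc(SCc3nc4ccccc4[nH]3)nc2n1` gives 220 nM in this assay.
Compound 3 `Cc1cc(Nc2ccc(C(=O)/C=C/c3ccc4ccccc4c3)cc2)n2nc(SCc3nc4ccccc4[nH]3)nc2n1` gives 5 nM in this assay.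

Among these three numbers compound 1 stands second highest: the nearest neighbour is compound 2, with a 2.6-fold higher number from compound 1 to compound 2 (0.41 log units; beyond the scatter), and the furthest is compound 3, with a 17-fold lower number from compound 1 to compound 3 (1.23 log units; beyond the scatter); between the other two there is a 44-fold lower number from compound 2 to compound 3 (1.64 log units; beyond the scatter).

Compound 4 `Cc1cc(Nc2ccc(C(=O)/C=C/c3ccc(-n4cccn4)cc3)cc2)n2nc(SCc3nc4ccccc4[nH]3)nc2n1` keeps the shared core of compound 1 and changes only the aryl ring of the enone: 1H-pyrazol-1-yl in place of fluoro on an aromatic carbon. Going by the values given here, two measured steps bear on this. Exchanging fluoro for trifluoromethoxy gave a modest rise in the number, while exchanging the whole 4-fluorophenyl for naphthalen-2-yl gave a large fall. The entering 1H-pyrazol-1-yl adds a second aromatic ring, as the naphthalen-2-yl change did, but as an attached five-membered ring rather than a fused one, so the expected step is a 1.9-fold lower number from compound 1 to compound 4 (0.28 log units; within the scatter), toward a lower number but smaller than for compound 3. Compound 4 is therefore estimated at 45 nM, with a range from 10 nM to 200 nM.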

Compound 4, half-maximal inhibitory concentration: 340 nM
For compound 4 the middle estimate is 7.6-fold (0.88 log units) below the measured one, outside the stated range (above it).
By their numbers in this assay, from the lowest: compound 3; then compound 1; then compounds 2 and 4 (each within the scatter of the next).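

A second aromatic ring at this position does not by itself lower the number: 1H-pyrazol-1-yl in place of fluoro gives a 4.0-fold higher number from compound 1 to compound 4 (0.60 log units; beyond the scatter), while the change from the fused naphthalen-2-yl to the attached ring of compound 4 gives a 68-fold higher number from compound 3 to compound 4 (1.83 log units; beyond the scatter). 1H-pyrazol-1-yl and trifluoromethoxy cannot be told apart here, with a 1.5-fold higher number from compound 2 to compound 4 (0.19 log units; within the scatter), so both replacements of fluoro on this aromatic carbon raise the number to a similar level. Nothing at hand explains the wide gap between the attached and the fused ring.

From the compounds shown here alone, it remains open whether the low number of compound 3 depends on the fused ring as such, which a quinoline ring could test. Also open, going by these compounds, is how methoxy or an amine on this aromatic carbon would compare with fluoro.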